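Hydroxyphenyl for dimethoxyphenyl: cytotoxicity notes on ester pair

A few compounds are considered here, and "the series" means these few. Any claim that something is new, unique, unknown or untested is made for them only; others in the source may bear on it.

Three members of the series have been run in an ADME assay on HepG2 cells (Homo sapiens) for cytotoxicity, read by CellTiter-Glo and resazurin assay, with a stated time of 72 h; on this read-out higher numbers stand for an effect only at larger amounts of compound and lower numbers for an effect already at smaller amounts. Compound 1 `COc1cc(OC)cc(-c2ccc(C(=O)N(Cc3cccc(OCCCCCC(=O)O)c3)C(C)C)cc2)c1` carries a free carboxylic acid on the chain and a 3,5-dimethoxyphenyl on the shared core. In this assay compound 1 gives only a limit, > 26000 nM. Compound 2 `CC(C)N(Cc1cccc(OCCCCCC(=O)O)c1)C(=O)c1ccc(-c2cccc(O)c2)cc1` differs from compound 1 as 3-hydroxyphenyl in place of 3,5-dimethoxyphenyl on an aromatic carbon. In this assay compound 2 likewise gives only a limit, > 26000 nM. The step that the two limits leave unreadable from compound 1 to compound 2 is therefore not readable in size. Compound 3 `CCOC(=O)CCCCCOc1cccc(CN(C(=O)c2ccc(-c3cc(OC)cc(OC)c3)cc2)C(C)C)c1` differs from compound 1 as ethyl in place of hydrogen on an oxygen next to a carbonyl group; this is the whole difference between the two cores. In this assay compound 3 also gives only a limit, > 26000 nM. The step that the two limits leave unreadable from compound 1 to compound 3 is equally not readable. Going by the values given here, the one piece of evidence across the set is the limit of > 26000 nM in this assay, at which 3 of the 3 values shown sit.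

Compound 4 `CCOC(=O)CCCCCOc1cccc(CN(C(=O)c2ccc(-c3cccc(O)c3)cc2)C(C)C)c1` has not yet been measured. Among the compounds with values here, it differs from compound 3 as 3-hydroxyphenyl in place of 3,5-dimethoxyphenyl on an aromatic carbon, the same change as the one from compound 1 to compound 2, at a place described in identical words. Compound 4 is expected to show a step that the limit leaves unreadable from compound 3 to compound 4 against compound 3, an estimate that rests on compound 1 and compound 2 both sitting at the limit (the limit of > 26000 nM in this assay, at which 3 of the 3 values shown sit). Compound 4 is therefore estimated at 30000 nM, with a range from 15000 nM to 60000 nM, and most likely the assay will again report only a limit.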

Compound 4, half-maximal effective concentration: > 26000 nM
Compound 4 ended at the assay's limit (the forecaster's own chance of this, stated with the estimate: 85%); the middle value does not contradict the limit.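

The steps from compound 3 to compound 4 and from compound 2 to compound 4 cannot be read in size, and no new comparison follows from them: the limit of > 26000 nM in this assay, at which 4 of the 4 values shown sit.

The compounds shown leave open where any of the four would give a readable value in this assay, and whether either change, 3-hydroxyphenyl for 3,5-dimethoxyphenyl or ethyl for hydrogen, alters that value.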